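This account rests on a few compounds, and the source may have more. Where it says the series, first, only, none or still open, it means among the compounds named here.

Compound 1 `COc1ccc(/C=C/C(=O)CC(C)=O)cc1` carries a methoxy group on its aromatic ring and an open diketone side chain. In a functional assay on DU-145 cells (Homo sapiens) for cytotoxicity, read by MTT assay, with a stated time of 72 h (a lower number here means a stronger inhibitor, a higher number a weaker inhibitor), compound 1 gives 9100 nM. Compound 2 `COc1ccc(/C=C/c2cc(C)no2)cc1` carries the same methoxy group on a different core; the difference between the two cores is not broken down here. In this assay compound 2 reaches only a limit, > 100000 nM. That value is the limit (the limit of > 100000 nM in this assay, at which 1 of the 3 values shown sits). Compound 3 `Cc1cc(/C=C/c2ccc(O)cc2)on1` differs from compound 2 in one place: hydrogen in place of methyl on an oxygen on an aromatic ring. In this assay compound 3 gives 67200 nM. That single change produced an at least 1.4-fold lower number from compound 2 to compound 3 (0.17 log units; that floor lies within the scatter), so its true size is not pinned down. Among the two numbers in hand, compound 1 stands lowest, and compound 3 is nearest to it at a clearly higher number.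

Compound 4 `CC(=O)CC(=O)/C=C/c1ccc(O)cc1` is compound 1 with the same change applied: hydrogen in place of methyl on an oxygen on an aromatic ring. The place of the change is the same in both pairs, so the change is the same one. Since the step from compound 2 to compound 3 was an at least 1.4-fold lower number from compound 2 to compound 3 (0.17 log units; that floor lies within the scatter), with a floor inside the usual scatter, the step expected from compound 1 to compound 4 in this assay is modest, a 1.3-fold lower number from compound 1 to compound 4 (0.11 log units; within the scatter). Compound 4 is therefore expected to give about 7000 nM in this assay. The estimate for compound 4 is expected to fall between 3000 nM and 20000 nM.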

Compound 4, half-maximal inhibitory concentration: 8800 nM
Estimate against measurement, compound 4: 1.3-fold (0.10 log units) below, within the range that was stated.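

In this assay the change of methoxy to hydroxy on the open diketone side chain gave a 1.0-fold lower number from compound 1 to compound 4 (0.01 log units; within the scatter), so on this core the hydroxy compound and its methoxy partner cannot be told apart. Set beside the same change on the other core, this result neither shows that the change carries over with the same size nor shows that its size depends on the core: the same change on two cores in this assay, an at least 1.4-fold lower number (0.17 log units; that floor lies within the scatter) from compound 2 to compound 3 and a 1.0-fold lower number (0.01 log units; within the scatter) from compound 1 to compound 4; the limit leaves it open whether they differ. Compound 2 stands at a limit and not at a number, so the step on that core has only a floor, and the comparison stays open for that reason: the limit of > 100000 nM in this assay, at which 1 of the 4 values shown sits.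

The compounds shown leave open how large the step from the methoxy to the hydroxy compound really is on the core of compound 2, and whether it would stay as small there as it does on the core of compound 1. They also leave open how this assay would respond to a different group on that aromatic ring, such as an amine or a carboxylic acid, or to a longer chain on the oxygen, such as ethoxy, on either core.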